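The compounds below may be only part of what the source reports. "The series", "measured", "known", "first", "only" and "open" are said of these compounds alone.

Two compounds have been measured in a functional assay for inhibition of sodium/hydrogen exchanger (Oryctolagus cuniculus); a higher number here means a weaker inhibitor, a lower number a stronger inhibitor:

compound 1, `Cc1cc(Br)c(S(C)(=O)=O)cc1C(=O)N=C(N)N`, giving 12 nM
compound 2, `Cc1cc(C)c(S(C)(=O)=O)cc1C(=O)N=C(N)N`, giving 11 nM

Compound 1 has the highest of these two numbers, with compound 2 nearest, but the step of a 1.1-fold lower number from compound 1 to compound 2 (0.04 log units; within the scatter) lies within the scatter, so the two cannot be placed in any order. Compound 3, `CCCSc1cc(C)c(C(=O)N=C(N)N)cc1S(C)(=O)=O`, differs from compound 1 at a single place: propylsulfanyl in place of bromo on an aromatic carbon. Among the measured compounds shown here, the only measured step that bears on this position is a 1.1-fold lower number from compound 1 to compound 2 (0.04 log units; within the scatter), and it was small. Propylsulfanyl is a longer group than methyl, and nothing measured here tests a group of that kind at this carbon, so the expectation rests on compound 1 alone and carries a wide range. The step of a 1.7-fold higher number from compound 1 to compound 3 (0.22 log units; within the scatter) is expected to stay modest, leaning toward a slightly higher number. For compound 3 the estimate in this assay is 20 nM, with a range from 6 nM to 70 nM.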

Compound 3, half-maximal inhibitory concentration: 6.8 nM
Compound 3: middle estimate off by 2.9-fold (0.47 log units), on the high side; measured number inside the range.
By their numbers in this assay, from the lowest: compounds 3, 2 and 1 (each within the scatter of the next).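

Until now, this carbon had carried only bromo and methyl, each a single heavy atom. Compound 3 shows that propylsulfanyl, with 4 heavy atoms including a sulfur, can stand here in this assay without moving the number beyond the scatter, whether set against bromo (a 1.8-fold lower number from compound 1 to compound 3 (0.25 log units; within the scatter)) or against methyl (a 1.6-fold lower number from compound 2 to compound 3 (0.21 log units; within the scatter)). Nothing available explains why the number holds through this change.

From the compounds shown here alone, how far this holds remains open, since a single chain cannot show where the limit lies at this carbon. A longer chain such as hexylsulfanyl, a phenylsulfanyl group, an amine or a carboxylic acid placed here might give a very different number.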